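Amide aryl swap on the pyridine N-oxide piperidine series

The compounds below may be only part of what the source reports. "The series", "measured", "known", "first", "only" and "open" are said of these compounds alone.

Measured so far in a functional assay on HEK293 cells for agonist activity at D(4) dopamine receptor (Homo sapiens), read by FLIPR; a higher number here means that more compound is needed for the effect, a lower number that less compound is needed:
compound 1 `O=C(NCN1CCC(c2cccc[n+]2[O-])CC1)c1cnccc1Cl`: 1290 nM
compound 2 `Cc1cc(C)cc(C(=O)NCN2CCC(c3cccc[n+]3[O-])CC2)c1`: 90 nM

Compound 2 stands at the lowest of the two numbers in this assay; its nearest neighbour is compound 1, and the step of a 14-fold lower number from compound 1 to compound 2 (1.16 log units; beyond the scatter) is the only one measured. That step shows that the group on the carbonyl carbon governs the read-out strongly, but it compares an aryl group with a heteroaryl group and says nothing about moving substituents around a single benzene ring.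

Compound 3 `Cc1ccc(C(=O)NCN2CCC(c3cccc[n+]3[O-])CC2)cc1C` is not yet measured. It differs from compound 2 by 3,4-dimethylphenyl in place of 3,5-dimethylphenyl on a carbonyl carbon; the two have the same atoms, joined differently. Going by the values given here, no measured step bears directly on this kind of change, so the expectation rests on compound 2 alone and is loose. A small shift is expected, most likely toward a somewhat higher number, as a 1.7-fold higher number from compound 2 to compound 3 (0.22 log units; within the scatter), and not far beyond the scatter.

For compound 3 in this assay the number is estimated at 150 nM, with a range from 45 nM to 500 nM.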

Compound 3, half-maximal effective concentration: 38 nM
Compound 3: the middle estimate sits 3.9-fold (0.60 log units) above what was measured, outside the stated range (below it).
By their numbers in this assay, from the lowest: compound 3; then compound 2; then compound 1.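

In this assay, the arrangement of the two methyl groups on the ring at the carbonyl carbon matters in its own right: with the same atoms joined differently, 3,4-dimethylphenyl in place of 3,5-dimethylphenyl gives a 2.4-fold lower number from compound 2 to compound 3 (0.37 log units; beyond the scatter), a modest step but one beyond the scatter. The earlier comparison set a benzene ring against a heteroaryl group, whereas this one keeps the ring and both methyl groups and changes only how they are arranged; against 4-chloropyridin-3-yl, the 3,4-dimethylphenyl group gives a 34-fold lower number from compound 1 to compound 3 (1.53 log units; beyond the scatter), which places compound 3 lowest of the three. Nothing available explains why the 3,4-dimethylphenyl arrangement gives the lower number.

The compounds shown leave open whether both methyl groups are needed, or whether a single methyl group on the ring would give a similar number. They also leave open whether methoxy or chlorine could replace the methyl groups on the 3,4-dimethylphenyl ring, and whether the preference for this arrangement would survive a change elsewhere on the shared core.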